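Sulfur substituent swap from compound 2 to compound 4

A few compounds are considered here, and "the series" means these few. Any claim that something is new, unique, unknown or untested is made for them only; others in the source may bear on it.

Values so far in a functional assay on HT-29 cells (Homo sapiens) for cytotoxicity, read by MTT assay, with a stated time of 24 h; a lower number here means a stronger inhibitor, a higher number a weaker inhibitor
compound 1 `Cn1c(-c2ccc(NC(=O)CSc3nc4cc(Cl)ccc4o3)cc2)nc(-c2ccccc2)c1-c1ccccc1` gives 20.6 ug/mL
compound 2 `Cn1cnnc1SCC(=O)Nc1ccc(-c2nc(-c3ccccc3)c(-c3ccccc3)n2C)cc1` gives 10.7 ug/mL
compound 3 `Cn1nnnc1SCC(=O)Nc1ccc(-c2nc(-c3ccccc3)c(-c3ccccc3)n2C)cc1` gives 1.6 ug/mL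

Compound 2 stands at 10.7 ug/mL in the upper part of this small range, level with compound 1 within the scatter (a 1.9-fold lower number from compound 1 to compound 2 (0.28 log units; within the scatter)) and clearly apart from compound 3 (a 6.7-fold lower number from compound 2 to compound 3 (0.83 log units; beyond the scatter)).

Compound 4 `Cn1ccnc1SCC(=O)Nc1ccc(-c2nc(-c3ccccc3)c(-c3ccccc3)n2C)cc1` differs from compound 2 at one place (1-methyl-1H-imidazol-2-yl in place of 4-methyl-4H-1,2,4-triazol-3-yl on a sulfur). Within the data shown here, no measured step covers this exact exchange. The closest is a 6.7-fold lower number from compound 2 to compound 3 (0.83 log units; beyond the scatter), where one five-membered aromatic ring on the sulfur replaces another. It shows that such an exchange can matter, though its direction does not transfer directly. The exchange in a 13-fold lower number from compound 1 to compound 3 (1.11 log units; beyond the scatter) is large, whereas a 1.9-fold lower number from compound 1 to compound 2 (0.28 log units; within the scatter) stays within the scatter despite a different group on the sulfur. The estimated step in this assay is a 1.3-fold higher number from compound 2 to compound 4 (0.12 log units; within the scatter), so none beyond the scatter is expected. Compound 4 is expected at 14 ug/mL (estimated range 5 ug/mL to 40 ug/mL).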

Compound 4, half-maximal inhibitory concentration: 47.5 ug/mL
The estimate for compound 4 lay 3.4-fold (0.53 log units) below the measured number, outside the stated range (above it).
By their numbers in this assay, from the lowest: compound 3; then compounds 2 and 1 (each within the scatter of the next); then compound 4.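

In this assay, the group on the sulfur matters even between rings of equal size: a 4.4-fold higher number from compound 2 to compound 4 (0.65 log units; beyond the scatter), although the exchange keeps 6 heavy atoms and changes the ring count only from 3 nitrogen to 2 nitrogen. The span across the series widens to a 30-fold higher number from compound 3 to compound 4 (1.47 log units; beyond the scatter), and 1-methyl-1H-imidazol-2-yl now ranks behind even 5-chloro-1,3-benzoxazol-2-yl, a 2.3-fold higher number from compound 1 to compound 4 (0.36 log units; beyond the scatter), making compound 4 the weakest of the set. Nothing available here explains why this single exchange has so large an effect.

The compounds shown leave open whether a phenyl ring, a carboxylic acid or an amine-bearing chain on the sulfur would fit this ranking. They also leave open whether the ranking of these rings would hold on a different core.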